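Adding a Second Chloro to the Core of Compound 2

A few compounds are considered here, and "the series" means these few. Any claim that something is new, unique, unknown or untested is made for them only; others in the source may bear on it.

Compound 2 `ClCc1cccc(Cn2cnc3ncnc(Cl)c32)c1` carries a chloromethyl-benzyl group on a fused two-ring core. In a functional assay on PC-3 cells (Homo sapiens) for cytotoxicity, read by sulforhodamine B assay, with a stated time of 48 h (a lower number here means that less compound is tolerated, a higher number that more compound is tolerated), compound 2 gives 63100 nM, the highest of the two numbers obtained. Compound 3 `ClCc1ccc(Cn2cnc3c(Cl)nc(Cl)nc32)cc1` gives 45700 nM, which lies within the scatter of compound 2. Compound 1 `ClCc1ccc(Cn2cnc3c(Cl)ncnc32)cc1` gives only a limit, > 100000 nM, so the limit of > 100000 nM in this assay, at which 1 of the 3 values shown sits, is all that is known of it. Compound 4 `ClCc1cccc(Cn2cnc3nc(Cl)nc(Cl)c32)c1` differs from compound 2 by chloro in place of hydrogen on an aromatic carbon. Among the measured compounds shown here, the one measured step of this kind is an at least 2.1-fold lower number from compound 1 to compound 3 (0.34 log units; beyond the scatter), which runs toward a lower number. Compound 4 is therefore expected to show a modest step toward a lower number, a 2.1-fold lower number from compound 2 to compound 4 (0.32 log units; beyond the scatter). Compound 4 is estimated to give about 30000 nM, between 10000 nM and 80000 nM.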

Compound 4, concentration lethal to 50% of the cells: 5370 nM
Estimate against measurement, compound 4: 5.6-fold (0.75 log units) above; the measured number lies below the stated range.
By their numbers in this assay, from the lowest: compound 4; then compounds 3 and 2 (each within the scatter of the next). At a limit, above all of these: compound 1.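

Chloro on the aromatic carbon between two ring nitrogen atoms can matter a great deal in this assay: a 12-fold lower number from compound 2 to compound 4 (1.07 log units; beyond the scatter). Until now this change had been read only against a limit, whereas this step has a measured number at both ends. Whether the change counts for more on one core than on the other remains unsettled: the same change on two cores in this assay, an at least 2.1-fold lower number (0.34 log units; beyond the scatter) from compound 1 to compound 3 and a 12-fold lower number (1.07 log units; beyond the scatter) from compound 2 to compound 4; the limit leaves it open whether they differ

The compounds shown leave open what an amine or a methoxy group would give at this position in place of chloro.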